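Swapping acetamido for carboxy on the core: expected exposure

The compounds below may be only part of what the source reports. "The series", "measured", "known", "first", "only" and "open" are said of these compounds alone.

Compound 1 `CCCCN(c1nc2c(NC(C)=O)cccc2o1)[C@H](C)c1ccc(-c2ccccc2-c2nnn[nH]2)cc1`: 41.6 ng.h/mL
Compound 2 `C[C@H](c1ccc(-c2cc(F)ccc2-c2nc(=O)o[nH]2)cc1)N(CC1CC1)c1nc2c(C(=O)O)cccc2o1`: 4410 ng.h/mL

In an ADME assay on the whole organism (Macaca fascicularis) for pharmacokinetics, read by LC-MS, using cassette dosing, at a dose of 1 mg/kg by the oral route (a lower number here means less compound in the circulation, a higher number more compound in the circulation at the dose given), compound 1 gives 41.6 ng.h/mL, the lower of the two numbers measured; compound 2 gives 4410 ng.h/mL, a gap well beyond the scatter, though the two structures differ in several places. Compound 3 `CCCCN(c1nc2c(C(=O)O)cccc2o1)[C@H](C)c1ccc(-c2ccccc2-c2nnn[nH]2)cc1` differs from compound 1 in one place only: carboxy in place of acetamido on an aromatic carbon. Going by the values given here, no step between two measured compounds shows what this change alone does. Since compound 2, the compound that also carries a carboxy, gives 4410 ng.h/mL, the step is expected to be upward and beyond the scatter: a 9.6-fold higher number from compound 1 to compound 3 (0.98 log units; beyond the scatter). Compound 3 is expected to give 400 ng.h/mL, between 60 ng.h/mL and 2500 ng.h/mL.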

Compound 3, area under the concentration-time curve: 429 ng.h/mL
For compound 3 the middle estimate is 1.1-fold (0.03 log units) below the measured one; low and high end bracket the measured number.
By their numbers in this assay, from the lowest: compound 1; then compound 3; then compound 2.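

In this assay, carboxy in place of acetamido on this aromatic carbon, with the rest of the molecule unchanged, gives a 10-fold higher number from compound 1 to compound 3 (1.01 log units; beyond the scatter). Going by these compounds alone, the earlier pair differed in several places, so this is the first reading of the swap alone, and it shows that this single position can carry a large change in the number. Nothing measured here explains why the number rises. As far as these compounds go, whether a primary amide or a methyl ester on the same carbon would land nearer compound 1 or compound 3 remains open. So does the size of this swap on a molecule with the other parts of compound 2.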